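The source may report more compounds than this note shows. Statements on the series, on what has been measured and on what is new or still open speak of the compounds shown alone.

In a toxicity assay on HepG2 2.2.15 cells (Homo sapiens) for cytotoxicity, read by CellTiter-Glo (a lower number here means that less compound is tolerated, a higher number that more compound is tolerated), compound 2 `O=C1CC(c2nccs2)CN1c1cnn2c1CN(C(=O)Nc1cc(F)c(F)c(F)c1)C(C1CC1)C2` gives 115000 nM and compound 1 `O=C1CC(c2cnco2)CN1c1cnn2c1CN(C(=O)Nc1cc(F)c(F)c(F)c1)C(C1CC1)C2` gives 139000 nM, two values within the scatter of each other. The next change leads to compound 3 `O=C1CC(c2ncccn2)CN1c1cnn2c1CN(C(=O)Nc1cc(F)c(F)c(F)c1)C(C1CC1)C2`, with pyrimidin-2-yl in place of 1,3-thiazol-2-yl on a saturated ring carbon. Among the measured compounds shown here, the only measured step at this place is a 1.2-fold lower number from compound 1 to compound 2 (0.08 log units; within the scatter), which stays within the scatter, so no step beyond the scatter is expected in this assay. The expected step is a 1.0-fold higher number from compound 2 to compound 3 (0.02 log units; within the scatter). For compound 3 the estimated value is 120000 nM, with an expected range of 65000 nM to 200000 nM.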

Compound 3, half-maximal cytotoxic concentration: > 200000 nM
Compound 3: only a limit was reported; the forecaster's own chance of this, stated with the estimate: 15%; at least 1.6-fold (0.22 log units) between middle value and limit.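

In this assay compound 3 gives > 200000 nM, which is a limit of the assay and not a measured number. The steps to it, an at least 1.7-fold higher number from compound 2 to compound 3 (0.24 log units; that floor lies within the scatter) and an at least 1.4-fold higher number from compound 1 to compound 3 (0.15 log units; that floor lies within the scatter), have floors that lie within the scatter, so this saturated ring carbon now also carries a six-membered aromatic ring, pyrimidin-2-yl, with no lower number than the five-membered rings gave. How far compound 3 truly lies from the others cannot be read, since the reading ends at the assay's ceiling: the limit of > 200000 nM in this assay, at which 1 of the 3 values shown sits.

As far as these compounds go, whether any group at this carbon lowers the number beyond the scatter stays open. An amine or a carboxylic acid on this carbon would test that.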